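Moving the pyridine nitrogen on a thioether pyrimidine scaffold

A few compounds are considered here, and "the series" means these few. Any claim that something is new, unique, unknown or untested is made for them only; others in the source may bear on it.

Compound 1: `Fc1ccc(Sc2ccnc(-c3ccccn3)n2)cc1F`, 1520 nM
Compound 2: `Clc1ccc(Sc2ccnc(-c3ccncc3)n2)cc1`, > 10000 nM

In a functional assay for inhibition of metabotropic glutamate receptor 5 (Homo sapiens), read by FLIPR and calcium flux (a higher number here means a weaker inhibitor, a lower number a stronger inhibitor), compound 1 gives 1520 nM. Compound 2 reaches only a limit in this assay, reported as > 10000 nM, and this is a limit rather than a measured number, as the limit of > 10000 nM in this assay, at which 1 of the 2 values shown sits, records. Compound 3, `Clc1ccc(Sc2ccnc(-c3cccnc3)n2)cc1`, differs from compound 2 in one place: pyridin-3-yl in place of pyridin-4-yl on an aromatic carbon. For the measured compounds named here, no measured pair shows this change, so no step size is on record, and compound 1 and compound 2 differ in more than one place, so their two values say nothing about it alone. The step from compound 2 to compound 3 in this assay is expected to be modest, if anything toward stronger inhibition, and the estimate implies an at least 1.2-fold lower number from compound 2 to compound 3 (0.09 log units; that floor lies within the scatter). Compound 3 is expected to give 8000 nM, with a range from 2000 nM to 30000 nM, and a fair chance that this assay again reports only a limit.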

Compound 3, half-maximal inhibitory concentration: > 10000 nM
Compound 3: no number, only a limit; the forecaster's own chance of this, stated with the estimate: 50%; middle value at least 1.2-fold (0.09 log units) away from the limit.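

Compound 2 and compound 3 both stand only at a limit in this assay, so no step between them can be read: the limit of > 10000 nM in this assay, at which 2 of the 3 values shown sit.

The compounds shown leave open whether pyridin-3-yl and pyridin-4-yl differ at all in this assay.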